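This account rests on a few compounds, and the source may have more. Where it says the series, first, only, none or still open, it means among the compounds named here.

Of the compounds shown here, three that share one core have already been measured in an assay on HEK293 cells for inhibition of solute carrier family 22 member 12 (Homo sapiens), read by scintillation counting, with stated times of 30 min and 15 min; on this read-out higher numbers stand for weaker inhibition and lower numbers for stronger inhibition. Compound 1 `CN(c1cnccc1SCCCCC(=O)O)c1ccc(C#N)c2ccccc12` gives 3580 nM. Compound 2 `CN(c1cnccc1SCCCCCC(=O)O)c1ccc(C#N)c2ccccc12` gives 3760 nM, and compound 3 `N#Cc1ccc(Nc2cnccc2SCCCCCC(=O)O)c2ccccc12` gives 4240 nM. Compound 2 thus stands second highest of the three numbers, yet both of its neighbours sit within the scatter of it: the step of a 1.1-fold higher number from compound 1 to compound 2 (0.02 log units; within the scatter) and the step of a 1.1-fold higher number from compound 2 to compound 3 (0.05 log units; within the scatter) show that neither extending the acid-bearing chain nor replacing the methyl on the ring nitrogen with hydrogen moved the number beyond ordinary repeat variation.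

Compound 4 `CN(c1cnccc1SC(C)(C)C(=O)O)c1ccc(C#N)c2ccccc12` has not yet been measured. It differs from compound 2 by 1-carboxy-1-methylethyl in place of 5-carboxypentyl on a sulfur, so the acid is now carried on a shorter, branched arm. Going by the values given here, the only measured step that touches this chain, a 1.1-fold higher number from compound 1 to compound 2 (0.02 log units; within the scatter), altered its length only slightly and stayed within the scatter; no measured step shortens the chain this far or introduces branching, so the existing numbers give little direct guidance. The estimate for compound 4 in this assay is therefore a tentative 7000 nM, with a range from 2000 nM to 25000 nM. That would correspond to an expected step of a 1.9-fold higher number from compound 2 to compound 4 (0.27 log units; within the scatter), a modest weakening that may or may not exceed the scatter.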

Compound 4, half-maximal inhibitory concentration: 5360 nM
Beside the measured number, compound 4's estimate is 1.3-fold (0.12 log units) above it; the range from low to high includes it.
By their numbers in this assay, from the lowest: compounds 1, 2, 3 and 4 (each within the scatter of the next).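

In this assay, going by these compounds alone, the arm on the sulfur can change much more than the earlier compounds showed: replacing 5-carboxypentyl with the shorter, branched 1-carboxy-1-methylethyl gives a 1.4-fold higher number from compound 2 to compound 4 (0.15 log units; within the scatter). The comparison with the 4-carboxybutyl arm gives the same picture, with a 1.5-fold higher number from compound 1 to compound 4 (0.18 log units; within the scatter), so these compounds show no clear difference between the two straight arms and the branched one, and this measurement can separate neither length nor branching as an influence on the result. No accompanying measurement offers an explanation for this result.

All of the arms shown end in a carboxylic acid, so it remains open whether the number would hold with an ester, a primary amide or a tetrazole in its place, or with no acid at all. Also open, from the compounds shown here alone, are a straight arm as short as carboxymethyl, which would separate length from branching, and an arm much longer than 5-carboxypentyl, which would show whether a change beyond the scatter can be reached at this sulfur.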